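Moving the Fluorine on the Phenyl Ring of Compound 1

This account rests on a few compounds, and the source may have more. Where it says the series, first, only, none or still open, it means among the compounds named here.

Compound 1 `Cc1nc(-c2ccccc2F)c(C(=O)N2CCN(c3cc(Cl)cc(Cl)c3)CC2)o1`: 82.3%
Compound 2 `Cc1nc(-c2ccccc2)c(C(=O)N2CCN(c3cccc(C)c3C)CC2)o1`: 29.8%

Both compounds were tested in an ADME assay (liver) for metabolic stability, with Liver microsome (Homo sapiens) as the target, read by LC-MS, using microsomes, with a stated time of 1 h, tested at 5 uM; a higher number here means that more of the compound is left, a lower number that less of the compound is left. Compound 1 gives 82.3%, the highest of the two numbers, while compound 2 gives 29.8%, a gap beyond the usual scatter. These two differ in several places, so no single change is tied to that gap. Compound 3 `Cc1nc(-c2ccc(F)cc2)c(C(=O)N2CCN(c3cc(Cl)cc(Cl)c3)CC2)o1` has not yet been measured. It differs from compound 1 in one place: 4-fluorophenyl in place of 2-fluorophenyl on an aromatic carbon. For the measured compounds named here, no measured pair shows what this change does, so only a small shift, if any, is expected. Compound 3 is estimated to give 72% in this assay, with a range from 50% to 90%. The expected step of a number 10.3 percentage points lower from compound 1 to compound 3 (beyond the scatter) is a slight drop, within the scatter.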

Compound 3, percent of the compound remaining: 71.8%
Estimate against measurement, compound 3: 0.2 percentage points above; measured number inside the range.
By their numbers in this assay, from the lowest: compound 2; then compound 3; then compound 1.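

Moving the fluorine from 2-fluorophenyl to 4-fluorophenyl gives the first single-change comparison in this assay, a modest step, a number 10.5 percentage points lower from compound 1 to compound 3 (beyond the scatter). With the same atoms joined differently, the place of the fluorine on this phenyl ring alone alters how much compound is left. Nothing at hand explains why this step occurs.

Still open, going by these compounds, is how a plain phenyl would compare with the rest of compound 1 unchanged. Also open, on these data alone, is what a nitrile or methoxy group would do in the fluorine's place.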